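A Nitro Group Added to Compound 3

This account rests on a few compounds, and the source may have more. Where it says the series, first, only, none or still open, it means among the compounds named here.

In a functional assay on Bel-7402 cells (Homo sapiens) for cytotoxicity, read by MTT assay, with a stated time of 48 h (a higher number here means a weaker inhibitor, a lower number a stronger inhibitor), compound 1 (`CCn1cc(-c2nc3ccccc3[nH]2)c(=O)c2cc(F)c(N3CCNC(C)C3)c(F)c21`) gives 30200 nM, compound 2 (`CCn1cc(-c2nc3ccccc3o2)c(=O)c2cc(F)c(Cl)cc21`) gives 28900 nM, and compound 3 (`CCn1cc(-c2nc3ccccc3o2)c(=O)c2cc(F)c(N3CCN(C)CC3)cc21`) gives 2000 nM. Compound 3 thus holds the lowest number of the three, well clear of the other two. The next compound, compound 4 (`CCn1cc(-c2nc3ccc([N+](=O)[O-])cc3o2)c(=O)c2cc(F)c(N3CCN(C)CC3)cc21`), has not yet been measured. It carries nitro in place of hydrogen on an aromatic carbon. For the measured compounds named here, the only measured step between compounds differing in one place is a 14-fold lower number from compound 2 to compound 3 (1.16 log units; beyond the scatter), a large step. It comes from 4-methylpiperazin-1-yl in place of chloro on an aromatic carbon, a different change from this one. Going by the values given here, no measured pair shows what nitro does in this assay, so neither a direction nor a size can be drawn from the data, and the expectation stays close to compound 3. The expected change is a 1.3-fold lower number from compound 3 to compound 4 (0.12 log units; within the scatter), which means no clear shift beyond the scatter. Compound 4 is estimated at 1500 nM, with an expected range from 400 nM to 6000 nM.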

Compound 4, half-maximal inhibitory concentration: 50200 nM
Compound 4: the middle estimate sits 33-fold (1.52 log units) below what was measured; the measured number lies above the stated range.
By their numbers in this assay, from the lowest: compound 3; then compounds 2, 1 and 4 (each within the scatter of the next).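

Nitro in place of hydrogen brings a 25-fold higher number from compound 3 to compound 4 (1.40 log units; beyond the scatter) in this assay, so this aromatic carbon, on a six-membered aromatic ring of carbon only that is part of a fused system, is not a silent place in this series. For the compounds shown here, the earlier step, a 14-fold lower number from compound 2 to compound 3 (1.16 log units; beyond the scatter), came from a change elsewhere on the molecule and went the other way, so this is the first sign that substitution on this ring can cost much of what compound 3 shows. No measurement at hand accounts for the rise.

With only nitro at this carbon, the compounds shown leave open whether any added group raises the number or whether this is particular to nitro. An amine or a methoxy group at the same carbon would separate those two readings.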